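The compounds below may be only part of what the source reports. "The series", "measured", "known", "first", "only" and "open" are said of these compounds alone.

Measured in a functional assay on HCC827 cells (Homo sapiens) for antiproliferative activity, read by MTT assay, with a stated time of 72 h; on this read-out lower numbers stand for stronger inhibition and higher numbers for weaker inhibition:
compound 1 `CN1CCN(c2ccc(Nc3ncc4nc(Nc5ccccc5)n([C@H]5CCN(C(=O)OC(C)(C)C)C5)c4n3)cc2)CC1` — 110 nM
compound 2 `CN1CCN(c2ccc(Nc3ncc4nc(Nc5ccccc5)n([C@H]5CCN(S(C)(=O)=O)C5)c4n3)cc2)CC1` — 17 nM
compound 3 `CN1CCN(c2ccc(Nc3ncc4nc(Nc5ccccc5)n([C@@H]5CCN(S(=O)(=O)C6CC6)C5)c4n3)cc2)CC1` — 0.88 nM

Compound 3 stands lowest of the three numbers in this assay; its nearest neighbour is compound 2 and the furthest is compound 1, both gaps beyond the scatter. Compound 4 `CC(=O)N1CC[C@H](n2c(Nc3ccccc3)nc3cnc(Nc4ccc(N5CCN(C)CC5)cc4)nc32)C1` is not yet measured and differs from compound 3 by 1-acetylpyrrolidin-3-yl in place of 1-(cyclopropylsulfonyl)pyrrolidin-3-yl on an aromatic nitrogen. Within the data shown here, two measured steps bear directly on this position. Replacing 1-(methylsulfonyl)pyrrolidin-3-yl by 1-(cyclopropylsulfonyl)pyrrolidin-3-yl gave a 19-fold lower number from compound 2 to compound 3 (1.29 log units; beyond the scatter), and replacing 1-(tert-butoxycarbonyl)pyrrolidin-3-yl by the same group gave a 130-fold lower number from compound 1 to compound 3 (2.10 log units; beyond the scatter). Within the amine substituents themselves, a 6.5-fold lower number from compound 1 to compound 2 (0.81 log units; beyond the scatter). Among the measured compounds shown here, the acetyl group of compound 4 shares the carbonyl with the tert-butoxycarbonyl of compound 1 and lacks the sulfonyl of compounds 2 and 3, so no measured compound gives a direct read on it. Because compound 3 is the low end of the series in this assay by a 19-fold lower number from compound 2 to compound 3 (1.29 log units; beyond the scatter), the step to compound 4 is expected to be a large rise, a 34-fold higher number from compound 3 to compound 4 (1.53 log units; beyond the scatter), toward the region of compound 2 and compound 1. Compound 4 is estimated at 30 nM in this assay, with a range from 8 nM to 120 nM.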

Compound 4, half-maximal inhibitory concentration: 260 nM
Beside the measured number, compound 4's estimate is 8.7-fold (0.94 log units) below it; the measured number lies above the stated range.
By their numbers in this assay, from the lowest: compound 3; then compound 2; then compound 1; then compound 4.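

In this assay the ranking now splits by the linking group: both sulfonyl compounds, compound 2 and compound 3, have lower numbers than both carbonyl compounds, compound 1 and compound 4, with a 15-fold higher number from compound 2 to compound 4 (1.18 log units; beyond the scatter) for acetyl in place of methylsulfonyl and a 300-fold higher number from compound 3 to compound 4 (2.47 log units; beyond the scatter) for 1-acetylpyrrolidin-3-yl in place of 1-(cyclopropylsulfonyl)pyrrolidin-3-yl. Among these compounds, the earlier compounds had only one carbonyl example, so the high number of compound 1 could have belonged to its tert-butoxy part, but methyl in place of tert-butoxy on a carbonyl carbon gives a 2.4-fold higher number from compound 1 to compound 4 (0.37 log units; beyond the scatter) and no recovery toward the sulfonyl compounds. Nothing available explains why these steps take this direction or size.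

With only four compounds, the sulfonyl and cyclopropyl contributions remain entangled: a cyclopropylcarbonyl group on the ring nitrogen would show how much of the low number of compound 3 survives without the sulfonyl. Also open, as far as these compounds go, is how a free pyrrolidine amine, a urea or a longer alkylsulfonyl chain such as propylsulfonyl would fall relative to these four compounds.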